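The source may hold more compounds than are shown below. What is called first, only, known or untested is meant among the compounds shown, and "the series" means these compounds.

Measured so far:
- compound 1, `N=C(N)c1ccc2cc(-c3cccc(OCCCCCOc4ccccc4)c3)oc2c1`: 4100 nM in an ADME assay on L6 cells (Rattus norvegicus) for cytotoxicity, read by resazurin assay, with a stated time of 70 h; a lower number here means a stronger inhibitor, a higher number a weaker inhibitor
- compound 2, `CC(C)NC(=N)c1ccc2cc(-c3cccc(OCCCCCOc4ccccc4)c3)oc2c1`: 20100 nM in this assay

Compound 2 stands at the highest of the two numbers in this assay; its nearest neighbour is compound 1, and the step of a 4.9-fold higher number from compound 1 to compound 2 (0.69 log units; beyond the scatter) came with isopropyl in place of hydrogen on an amine nitrogen, a step beyond the scatter.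

Compound 3, `c1ccc(OCCCCCOc2cccc(-c3cc4ccc(C5=NCCN5)cc4o3)c2)cc1`, has not been measured in this assay. Against compound 2 it shows (a group of 5 heavy atoms (3 carbon, 2 nitrogen; one five-membered non-aromatic ring with 2 hetero atoms) in place of a group of 6 heavy atoms (4 carbon, 2 nitrogen; no ring), on an aromatic carbon). The change therefore removes the isopropyl that separated compound 2 from compound 1 and closes the remaining two nitrogens into a five-membered non-aromatic ring. Among the compounds with values here, only one measured step bears on it: the step from compound 1 to compound 2, which raised the number beyond the scatter when the isopropyl entered. Reversing that entry suggests a lower number for compound 3 than for compound 2; how far the new ring itself shifts the number is unknown from these two compounds, so the expectation is held closer to compound 2 than a full return to compound 1 would be. Compound 3 is therefore expected at 8000 nM (range 3500 nM to 18000 nM), an expected step of a 2.5-fold lower number from compound 2 to compound 3 (0.40 log units; beyond the scatter).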

Compound 3, half-maximal inhibitory concentration: 3700 nM
For compound 3 the middle estimate is 2.2-fold (0.33 log units) above the measured one; low and high end bracket the measured number.
By their numbers in this assay, from the lowest: compounds 3 and 1 (each within the scatter of the next); then compound 2.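

In this assay, the five-membered ring on this aromatic carbon undoes the rise seen with the isopropyl compound (a 5.4-fold lower number from compound 2 to compound 3 (0.73 log units; beyond the scatter)) and leaves compound 3 level with the unsubstituted open group of compound 1 (a 1.1-fold lower number from compound 1 to compound 3 (0.04 log units; within the scatter)). The position therefore tolerates more than the open group without a change in the number, and carbon added around the two nitrogens does not by itself raise the number: in these three compounds, only the isopropyl compound, compound 2, stands apart. No measurement shown accounts for why the ring and the isopropyl group part ways in this assay.

On these data alone, whether the rise belongs to isopropyl alone or to any open substituent on the amine nitrogen remains open, and a methyl or a cyclopropyl group there would separate those readings. Also open, as far as these compounds go, are whether a six-membered ring in place of the five-membered one stays level with compound 1, and whether the match between ring and open group holds with a shorter chain in place of the shared one.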